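A few compounds are considered here, and "the series" means these few. Any claim that something is new, unique, unknown or untested is made for them only; others in the source may bear on it.

Compound 1 `COc1cc(Oc2ncc(C)s2)cc(-c2ccc3c(c2)CC[C@H](CCC(=O)O)O3)c1F` pairs a methoxy and a fluoro on the ring that carries the (5-methyl-1,3-thiazol-2-yl)oxy group. In a functional assay on HEK293 cells for agonist activity at Free fatty acid receptor 1 (Homo sapiens), read by HTRF and inositol phosphate accumulation, with a stated time of 60 min (on this read-out higher numbers stand for an effect only at larger amounts of compound and lower numbers for an effect already at smaller amounts), compound 1 gives > 10000 nM, which is a limit of the assay and not a number. Compound 2 `COc1cc(OC(F)(F)F)cc(-c2ccc3c(c2)CC[C@H](CCC(=O)O)O3)c1F` and compound 3 `COc1cc(OC2CCC2)cc(-c2ccc3c(c2)CC[C@H](CCC(=O)O)O3)c1F` vary only the group on that oxygen. In this assay compound 2 gives 4400 nM. In this assay compound 3 gives > 10000 nM, again a limit. The measured steps are an at least 2.2-fold lower number from compound 1 to compound 2 (0.35 log units; beyond the scatter) and an at least 2.2-fold higher number from compound 2 to compound 3 (0.35 log units; beyond the scatter), while a step that the two limits leave unreadable from compound 1 to compound 3; the limit of > 10000 nM in this assay, at which 2 of the 3 values shown sit, governs how much can be read. Compound 4 `Cc1cnc(Oc2cc(Cl)c(F)c(-c3ccc4c(c3)CC[C@H](CCC(=O)O)O4)c2)s1` keeps the oxygen substituent of compound 1 and changes a different position: chloro in place of methoxy on an aromatic carbon. Going by the values given here, no measured step touches this position, so the steps above do not bear on it; they show only that compound 1 sits at the limit and that one change elsewhere brought the value down. With no guidance in either direction, compound 4 is expected to stay near the limit, estimated at 9000 nM with a range of 3000 nM to 30000 nM. This estimate corresponds to an expected step of an at least 1.1-fold lower number from compound 1 to compound 4 (0.04 log units; that floor lies within the scatter).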

Compound 4, half-maximal effective concentration: > 10000 nM
Compound 4 was reported as a limit (the forecaster's own chance of this, stated with the estimate: 60%); middle value at least 1.1-fold (0.04 log units) from the limit.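

In this assay compound 4 gives > 10000 nM, a limit and not a number. Compound 1 also stands at a limit, so no step can be read between compound 1 and compound 4: the limit of > 10000 nM in this assay, at which 3 of the 4 values shown sit.

The compounds shown leave open whether chloro in place of methoxy changes the value at all, including with the trifluoromethyl group of compound 2 on the oxygen.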